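A few compounds are considered here, and "the series" means these few. Any claim that something is new, unique, unknown or untested is made for them only; others in the source may bear on it.

In an assay on isolated protein for inhibition of 3',5'-cyclic-AMP phosphodiesterase 4A (Cavia porcellus), read by cAMP accumulation, tested at 100 uM (a lower number here means a weaker effect, a higher number a stronger effect of the compound at the concentration tested), compound 1 `CC(=O)c1cc(C(=O)c2ccccc2)c(=O)[nH]c1C` gives 8.9%, compound 2 `O=C(c1ccccc1)c1cc(C(=O)c2ccccc2)c(=O)[nH]c1-c1ccccc1` gives 9.6%, and compound 3 `O=C1CCCc2[nH]c(=O)c(C(=O)c3ccccc3)cc21` gives 6%. Compound 3 holds the lowest of these three numbers, yet both other numbers lie within the scatter of it, so the three compounds cannot be separated on this evidence; all three show only a small effect at the concentration tested. Compound 4 `O=C1CC(c2ccccc2)Cc2[nH]c(=O)c(C(=O)c3ccccc3)cc21` differs from compound 3 by phenyl in place of hydrogen on a saturated ring carbon. Going by the values given here, no measured pair shows what such a change does in this assay, and the expected step is a number 2 percentage points higher from compound 3 to compound 4 (within the scatter), nothing beyond the scatter, the three measured numbers all lying close together. Compound 4 is therefore estimated to give 8% in this assay, with a range of 0% to 20%.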

Compound 4, a percentage reported as inhibition, at one concentration (the size of the read-out at that concentration, not a potency): 7.8%
Estimate against measurement, compound 4: 0.2 percentage points above; the measured number falls inside the stated range.
By their numbers in this assay, from the lowest: compounds 3, 4, 1 and 2 (each within the scatter of the next).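

Phenyl in place of hydrogen on a saturated ring carbon gives a number 1.8 percentage points higher from compound 3 to compound 4 (within the scatter) in this assay, the first step that can be read at this position. With phenyl on this carbon, the effect at the concentration tested stays small and cannot be told apart from that of compound 3. Nothing available offers an explanation for this result. From the compounds shown here alone, whether an amine or a carboxylic acid on the same ring carbon would give a step beyond the scatter remains open. So does whether a longer chain there would do so.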